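The source may report more compounds than this note shows. Statements on the series, on what has been measured and on what is new or still open speak of the compounds shown alone.

The three measured compounds, with their results in an assay on cell membranes for displacement of a labelled ligand from Sigma non-opioid intracellular receptor 1 (Cavia porcellus), read by scintillation counting (on this read-out higher numbers stand for weaker inhibition and lower numbers for stronger inhibition), are these:

compound 1 `COc1ccc(CNC(C)c2cc3c(cc2OC)OC(C)(C)C=C3)cc1`, giving 165 nM
compound 2 `COc1cc2c(cc1C(C)NC/C=C/c1ccccc1)C=CC(C)(C)O2`, giving 83 nM
compound 3 `CCNC(C)c1cc2c(cc1OC)OC(C)(C)C=C2`, giving 83 nM

Compound 3 stands level with compound 2, the two together at the low end of the three numbers; the larger gap in the set is a 2.0-fold lower number from compound 1 to compound 3 (0.30 log units; within the scatter), and between the other two it is no change at the digits printed from compound 2 to compound 3 (within the scatter). The whole set spans a narrow band: even a 2.0-fold lower number from compound 1 to compound 2 (0.30 log units; within the scatter) stays inside the scatter.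

Compound 4 `COc1cc2c(cc1C(C)N1CCCC1)C=CC(C)(C)O2` differs from compound 3 by pyrrolidin-1-yl in place of ethylamino on a saturated chain carbon bound to an aromatic carbon and a saturated chain carbon. Within the data shown here, none of the measured steps touches this spot: all three vary the group on the carbon bound to the amine nitrogen, and every one of them stayed within the scatter. Among the measured compounds shown here, no measured step converts the ethylamino into a ring, so a direct guide is lacking. Since the shared core with an amine at this position held near the same number through three variations, the expected step for compound 4 in this assay is none beyond the scatter, a 1.0-fold lower number from compound 3 to compound 4 (0.02 log units; within the scatter). Compound 4 is therefore estimated at 80 nM, with a range from 25 nM to 260 nM.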

Compound 4, inhibition constant: 19 nM
Compound 4: middle estimate off by 4.2-fold (0.62 log units), on the high side; measured number below the stated range.
By their numbers in this assay, from the lowest: compound 4; then compounds 2, 3 and 1 (each within the scatter of the next).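

In this assay, among these compounds, pyrrolidin-1-yl in place of ethylamino on a saturated chain carbon bound to an aromatic carbon and a saturated chain carbon gives the first step in the set that lies beyond the scatter: a 4.4-fold lower number from compound 3 to compound 4 (0.64 log units; beyond the scatter). Among the compounds shown here, the earlier steps, which exchanged only the group on the saturated chain carbon bound to the amine nitrogen, all stayed within the scatter, so this pair is the first to show the number moving with a change in these compounds. Nothing available here explains the step.

This single pair cannot separate the ring itself from the added carbons or from the loss of the hydrogen-bond donor. From the compounds shown here alone, whether piperidin-1-yl, morpholin-4-yl or open-chain diethylamino at the same place would give a step of similar size remains open.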